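Swapping fluoro for methyl on a weak binder

A few compounds are considered here, and "the series" means these few. Any claim that something is new, unique, unknown or untested is made for them only; others in the source may bear on it.

Compound 2 `Fc1ccc(-c2n[nH]cc2N2CCNCC2)cc1` is known in an assay on isolated protein for binding affinity to 5-hydroxytryptamine receptor 1D (Homo sapiens) (a lower number here means a stronger inhibitor, a higher number a weaker inhibitor), only as a limit of the measurement: in this assay compound 2 gives > 10000 nM. Compound 1 `c1ccc(-c2n[nH]cc2N2CCNCC2)cc1` is likewise known only as a limit, giving > 10000 nM in this assay. The step from compound 1 to compound 2 is a step that the two limits leave unreadable from compound 1 to compound 2, its size hidden because of the limit of > 10000 nM in this assay, at which 2 of the 2 values shown sit. Compound 3 `Cc1ccc(-c2n[nH]cc2N2CCNCC2)cc1` differs from compound 2 by methyl in place of fluoro on an aromatic carbon. For the measured compounds named here, no measured step shows what this change does, so compound 3 is expected to stay weak, with an estimated 20000 nM ranging from 5000 nM to 80000 nM. This amounts to an expected step that the limit leaves unreadable from compound 2 to compound 3.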

Compound 3, inhibition constant: 325 nM
Estimate against measurement, compound 3: 62-fold (1.79 log units) above; measured number outside the range, below it.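

In this assay, methyl para to a large group gives an at least 30-fold lower number from compound 2 to compound 3 (1.48 log units; beyond the scatter) and also an at least 30-fold lower number from compound 1 to compound 3 (1.48 log units; beyond the scatter). This place on the six-membered aromatic ring, where fluoro and hydrogen could not be told apart, can therefore carry measurable binding, and methyl separates clearly from both. On these data alone, the true size of both steps stays unknown because the starting values are only limits: the limit of > 10000 nM in this assay, at which 2 of the 3 values shown sit. As far as these compounds go, whether ethyl, methoxy or chloro at this place would match methyl remains open.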